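A few compounds are considered here, and "the series" means these few. Any claim that something is new, unique, unknown or untested is made for them only; others in the source may bear on it.

Measured so far:
compound 1 `COc1ccccc1S(=O)(=O)c1ccc(NC(=O)C(C)(O)C(F)(F)F)cc1` — 1600 nM
compound 2 `Cc1ccccc1S(=O)(=O)c1ccc(NC(=O)C(C)(O)C(F)(F)F)cc1` — 5100 nM

In a functional assay (Cavia porcellus) with sulfonylurea receptors; K-ATP channels (Homo sapiens) as the target (a lower number here means a stronger inhibitor, a higher number a weaker inhibitor), compound 1 gives 1600 nM and compound 2 gives 5100 nM. For the measured compounds named here, compound 2 holds the higher of the two numbers; the single measured step, a 3.2-fold higher number from compound 1 to compound 2 (0.50 log units; beyond the scatter), lies beyond the scatter. Compound 3 `CC(O)(C(=O)Nc1ccc(S(=O)(=O)c2ccc(Br)cc2)cc1)C(F)(F)F` differs from compound 2 by 4-bromophenyl in place of 2-methylphenyl on a sulfonyl sulfur. Going by the values given here, that step concerns a substituent on an aromatic carbon, not the ring on the sulfonyl sulfur, so no measured step bears directly on this change, and the expectation rests on the values alone. Compound 3 is therefore expected to lie near the measured pair, at 3000 nM (range 800 nM to 12000 nM), an expected step of a 1.7-fold lower number from compound 2 to compound 3 (0.23 log units; within the scatter) in this assay.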

Compound 3, half-maximal inhibitory concentration: > 30000 nM
Compound 3: no number, only a limit; the forecaster's own chance of this, stated with the estimate: 10%; middle value at least 10-fold (1.00 log units) away from the limit.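

Compound 3 gives no number in this assay, only a limit: the limit of > 30000 nM in this assay, at which 1 of the 3 values shown sits. On the sulfonyl sulfur, the change to 4-bromophenyl brings an at least 5.8-fold higher number from compound 2 to compound 3 (0.76 log units; beyond the scatter) from the 2-methylphenyl group and an at least 18-fold higher number from compound 1 to compound 3 (1.27 log units; beyond the scatter) from the 2-methoxyphenyl group. The earlier compounds shown here showed only a change of substituent on an aromatic carbon, whereas this result shows that the aryl group on the sulfonyl sulfur can take the value to the assay's limit. The compounds shown do not separate the effect of the bromine from that of its place on the ring. A plain phenyl or a 4-methoxyphenyl group on the sulfonyl sulfur would bear on that question.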